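A Chlorobenzyl Amide Whose Nearest Neighbour Has No Number

The source may report more compounds than this note shows. Statements on the series, on what has been measured and on what is new or still open speak of the compounds shown alone.

Compound 1 `CC(C)c1c(C(=O)N(C)Cc2cccc(F)c2)nn(-c2ccc(F)cc2)c1CC[C@@H](O)C[C@@H](O)CC(=O)O`: 1900 nM
Compound 2 `CC(C)c1c(C(=O)N2CCC[C@H](N3CCC4C=CC=CC4C3)C2)nn(-c2ccc(F)cc2)c1CC[C@@H](O)C[C@@H](O)CC(=O)O`: 1720 nM
Compound 3 `COc1ccc(CNC(=O)c2nn(-c3ccc(F)cc3)c(OC[C@@H](O)C[C@@H](O)CC(=O)O)c2C(C)C)cc1`: "not determined" (no result reported)

All numbers here come from a functional assay on L6 cells (Rattus norvegicus) for inhibition; on this read-out lower numbers stand for stronger inhibition and higher numbers for weaker inhibition. In this assay compound 1 gives 1900 nM and compound 2 gives 1720 nM; these two values sit within the usual scatter of each other, so neither can be placed above the other. Compound 3 stands nowhere on these numbers: no result was determined for it.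

Compound 4 `CC(C)c1c(C(=O)N(C)Cc2cccc(Cl)c2)nn(-c2ccc(F)cc2)c1OC[C@@H](O)C[C@@H](O)CC(=O)O` is built from compound 3 by a single change: (3-chlorobenzyl)(methyl)amino in place of (4-methoxybenzyl)amino on a carbonyl carbon. Among the measured compounds shown here, since compound 3 has no value, no measured step leads into compound 4, and no pair among the measured compounds shows this particular exchange, so no direction or size of step can be read from the data. What remains is a guess anchored on the measured compounds. Compound 4 is expected to land near 1500 nM, with a range from 400 nM to 6000 nM, because compound 1 carries a related (methyl)amino amide and gives 1900 nM.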

Compound 4, half-maximal inhibitory concentration: 2120 nM
Compound 4: middle estimate off by 1.4-fold (0.15 log units), on the low side; the range from low to high includes it.
By their numbers in this assay, from the lowest: compounds 2, 1 and 4 (each within the scatter of the next).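

In this assay, among the compounds shown here, compound 3 has no number, so no step to compound 4 can be read, and compound 4 differs from compounds 1 and 2 in more than one place. Nothing here accounts for the result of compound 4. On these data alone, what exchanging (4-methoxybenzyl)amino for (3-chlorobenzyl)(methyl)amino does on its own remains open.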